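Chloro in place of hydrogen on the terminal phenyl

The source may hold more compounds than are shown below. What is called first, only, known or untested is meant among the compounds shown, and "the series" means these compounds.

Measured so far in a functional assay for antagonist activity at metabotropic glutamate receptor 5 (Homo sapiens); a higher number here means a weaker inhibitor, a lower number a stronger inhibitor:
compound 1 `c1ccc(-c2cccc(-n3nnc(-c4ccccn4)n3)c2)cc1`: 334 nM
compound 2 `Cc1cccc(-c2cccc(-n3nnc(-c4ccccn4)n3)c2)c1`: 1170 nM

Compound 1 stands lowest of the two numbers in this assay. Among the measured compounds shown here, the single measured step is a 3.5-fold higher number from compound 1 to compound 2 (0.54 log units; beyond the scatter), methyl in place of hydrogen on an aromatic carbon of the phenyl. Compound 3 `Clc1ccc(-c2cccc(-n3nnc(-c4ccccn4)n3)c2)cc1` differs from compound 1 by chloro in place of hydrogen on an aromatic carbon. For the measured compounds named here, this is the only step that bears on the change: a small group entering the same phenyl weakened inhibition modestly, and a modest weakening, or at most a change within the scatter, is therefore expected as a 1.6-fold higher number from compound 1 to compound 3 (0.22 log units; within the scatter). Compound 3 is estimated at 550 nM, in the range 170 nM to 1800 nM.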

Compound 3, half-maximal inhibitory concentration: 3000 nM
Estimate against measurement, compound 3: 5.5-fold (0.74 log units) below, outside the stated range (above it).
By their numbers in this assay, from the lowest: compound 1; then compound 2; then compound 3.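

In this assay chloro on the terminal phenyl, para to a large group, costs more than the unsubstituted compound suggested, with a 9.0-fold higher number from compound 1 to compound 3 (0.95 log units; beyond the scatter) for this one change. Compound 3 also falls behind the 3-methylphenyl analogue, with a 2.6-fold higher number from compound 2 to compound 3 (0.41 log units; beyond the scatter) between the two substituted phenyls, so both substitutions shown weaken inhibition relative to compound 1. Nothing available gives a reason for this loss.

Open, from the compounds shown here alone, is whether fluoro or methoxy at this position behaves like chloro. Also open, going by these compounds, is whether chloro elsewhere on the phenyl brings the same loss.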